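Solubility notes on the anilide series: compound 4

The source may report more compounds than this note shows. Statements on the series, on what has been measured and on what is new or still open speak of the compounds shown alone.

Compound 3 `COc1ccc2nc(C)cc(OCC(=O)Nc3cccnc3)c2c1` sits lowest of the two numbers in a physicochemical assay for solubility, in phosphate buffer, measured as kinetic solubility, with a stated time of 1 h, at pH 7.4 (a lower number here means a less soluble compound, a higher number a more soluble compound), where compound 3 gives 32000 nM. Compound 1 `COc1ccc2nc(C)cc(OCC(=O)Nc3c(C)cccc3C)c2c1` gives 112000 nM. Compound 2 `COc1ccc2nc(C)cc(OCC(=O)Nc3ccc(Br)c(C)c3)c2c1` gives only a limit, < 1000 nM. Compound 4 `COc1ccc2nc(C)cc(OCC(=O)Nc3c(C)cncc3C)c2c1` differs from compound 3 by 3,5-dimethylpyridin-4-yl in place of pyridin-3-yl on an amide-type nitrogen. Of the measured steps, a 3.5-fold lower number from compound 1 to compound 3 (0.54 log units; beyond the scatter) is the one that bears on it, as 2,6-dimethylphenyl and 3,5-dimethylpyridin-4-yl share the two methyl groups named; an at least 110-fold lower number from compound 1 to compound 2 (2.04 log units; beyond the scatter) and an at least 32-fold higher number from compound 2 to compound 3 (1.50 log units; beyond the scatter) concern a bromine-bearing ring and speak less to this change. A modest rise, or none beyond the scatter, is expected in this assay. Compound 4 is estimated at 55000 nM, within 18000 nM to 160000 nM, an expected 1.7-fold higher number from compound 3 to compound 4 (0.24 log units; within the scatter).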

Compound 4, solubility: 12000 nM
Estimate against measurement, compound 4: 4.6-fold (0.66 log units) above; measured number below the stated range.
By their numbers in this assay, from the lowest: compound 4; then compound 3; then compound 1. At a limit, below all of these: compound 2.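

In this assay, 3,5-dimethylpyridin-4-yl on the amide-type nitrogen falls under pyridin-3-yl (a 2.7-fold lower number from compound 3 to compound 4 (0.43 log units; beyond the scatter)) and under 2,6-dimethylphenyl (a 9.3-fold lower number from compound 1 to compound 4 (0.97 log units; beyond the scatter)), so the two methyl groups do not carry the high number of compound 1 over to this ring. It still stands clear of 4-bromo-3-methylphenyl (an at least 12-fold higher number from compound 2 to compound 4 (1.07 log units; beyond the scatter)). Among these rings, neither the methyl groups nor the ring nitrogen alone tracks the number.

As far as these compounds go, an amine or a carboxylic acid on this ring stays open, as does an unsubstituted phenyl, which would separate the methyl groups from the ring nitrogen. Compound 2 gives a limit and not a number, so its true distance from the other compounds also stays open: the limit of < 1000 nM in this assay, at which 1 of the 4 values shown sits.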